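The source may report more compounds than this note shows. Statements on the series, on what has been measured and on what is new or still open speak of the compounds shown alone.

- compound 1 `Nc1ccccc1NC(=O)c1ccc(NC(=S)NCc2cccc(F)c2)cc1`: 74000 nM
- compound 2 `Nc1ccccc1NC(=O)c1ccc(NC(=S)NCc2cncc(F)c2)cc1`: 85000 nM

Among the measured compounds shown here, in a functional assay on MDA-MB-231 cells (Homo sapiens) for cytotoxicity, read by MTT assay, with a stated time of 72 h (on this read-out lower numbers stand for stronger inhibition and higher numbers for weaker inhibition), compound 2 gives 85000 nM, which is within the scatter of the only other measured compound, so the two cannot be ranked. The next compound to be measured is compound 3 `Nc1ccccc1NC(=O)c1ccc(NC(=S)NCc2cccc(Cl)c2)cc1`. It carries 3-chlorophenyl in place of 5-fluoropyridin-3-yl on a saturated chain carbon bound to an amide-type nitrogen.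

For the measured compounds named here, one measured step bears on this change: a 1.1-fold higher number from compound 1 to compound 2 (0.06 log units; within the scatter). That step put 5-fluoropyridin-3-yl in place of 3-fluorophenyl and stayed within the scatter. Going by the values given here, no measured compound carries chlorine, so this evidence is thin, and no clear shift is expected in this assay. The expected change is small, within the scatter: a 1.3-fold lower number from compound 2 to compound 3 (0.12 log units; within the scatter). For compound 3 the estimated value is 65000 nM, with an expected range of 30000 nM to 110000 nM.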

Compound 3, half-maximal inhibitory concentration: 92000 nM
For compound 3 the middle estimate is 1.4-fold (0.15 log units) below the measured one; the measured number falls inside the stated range.
By their numbers in this assay, from the lowest: compounds 1, 2 and 3 (each within the scatter of the next).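

In this assay, chloro in place of fluoro on an aromatic carbon gives a 1.2-fold higher number from compound 1 to compound 3 (0.09 log units; within the scatter), so this halogen swap on its own leaves the number within the scatter. 3-Chlorophenyl in place of 5-fluoropyridin-3-yl gives a 1.1-fold higher number from compound 2 to compound 3 (0.03 log units; within the scatter), and this change also stays within the scatter, even though it alters both the halogen and the ring nitrogen at once. The three groups on this saturated chain carbon therefore cannot be ranked, and no measurement on hand explains why the values stay so close.

The compounds shown leave open whether a different kind of group here, such as an amine or a carboxylic acid on the ring, would move the number beyond the scatter. They also leave open what a longer chain to the ring would do.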